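A few compounds are considered here, and "the series" means these few. Any claim that something is new, unique, unknown or untested is made for them only; others in the source may bear on it.

Compounds measured so far:
compound 1, `CC(C)[C@@H](C[C@H]1SC(=O)NC1=O)c1ccc(-c2ccc3cccc(F)c3c2)[nH]c1=O`, 6 nM
compound 2, `CC(C)[C@H](C[C@H]1OC(=O)NC1=O)c1ccc(-c2ccc3cccc(F)c3c2)[nH]c1=O`, 6 nM
compound 3, `CC(C)[C@@H](c1ccc(-c2ccc3cccc(F)c3c2)[nH]c1=O)[C@H]1OC(=O)NC1=O`, 27 nM

In an assay on membranes from Chem-1 cells for displacement of a labelled ligand from prostaglandin E2 receptor EP3 subtype (Homo sapiens), read by scintillation counting, with a stated time of 2 h (a lower number here means a stronger inhibitor, a higher number a weaker inhibitor), compound 1 and compound 2 give the same number, and compound 3 stands at the highest value of the three. Going by the values given here, the one change that has been followed within this set is the step in which the ring is moved directly onto the chain carbon: a 4.5-fold higher number from compound 2 to compound 3 (0.65 log units; beyond the scatter).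

Compound 4, `CC(C)[C@@H](c1ccc(-c2ccc3cccc(F)c3c2)[nH]c1=O)[C@@H]1OC(=O)NC1=O`, is the next compound to be tested. The difference from compound 3 is confined to configuration: the two compounds have the same atoms and bonds and differ only in configuration as drawn: 1 of 2 stereo elements differ; a stereocentre at a saturated ring carbon is drawn R in compound 3 and S in compound 4.

Among the compounds with values here, none of the measured steps concerns a change of configuration alone, so no measured step bears directly on this one. Within the data shown here, compound 1 and compound 2 show the same number, but they differ in more than one way and no single step joins them. Among the measured compounds shown here, the only guidance is that the ring carbon of compound 3 is now drawn in the other configuration, and such an inversion may move the number in either direction. Compound 4 is therefore expected to land in this assay at about 40 nM, within a range of 8 nM to 200 nM, which corresponds to an expected step of a 1.5-fold higher number from compound 3 to compound 4 (0.17 log units; within the scatter).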

Compound 4, inhibition constant in the prostaglandin E2 receptor EP3 subtype assay: 85 nM
Beside the measured number, compound 4's estimate is 2.1-fold (0.33 log units) below it; the measured number falls inside the stated range.
By their numbers in the prostaglandin E2 receptor EP3 subtype assay, from the lowest: compounds 1 and 2 (each within the scatter of the next); then compound 3; then compound 4.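

In the prostaglandin E2 receptor EP3 subtype assay, inverting the stereocentre at the saturated ring carbon gives a 3.1-fold higher number from compound 3 to compound 4 (0.50 log units; beyond the scatter), the first measured effect of configuration alone at this position, and the step can be assigned to that single centre: the fact that compounds 3 and 4 differ only in the configuration as drawn. In the prostaglandin E2 receptor EP3 subtype assay, the replacement of (2,4-dioxo-1,3-oxazolidin-5-yl)methyl by 2,4-dioxo-1,3-oxazolidin-5-yl therefore has a size that depends on the configuration of the ring carbon, giving a 14-fold higher number from compound 2 to compound 4 (1.15 log units; beyond the scatter) with the S ring carbon, against a 4.5-fold higher number from compound 2 to compound 3 (0.65 log units; beyond the scatter) with the R ring carbon. In a physicochemical assay for solubility, measured as kinetic solubility, at pH 2 (on this read-out lower numbers stand for lower solubility and higher numbers for higher solubility), compound 3 gives 5400 nM and compound 4 gives 6900 nM, two values within the scatter of each other, so the inversion separates this pair in the prostaglandin E2 receptor EP3 subtype assay but not on this read-out.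

The compounds shown leave open whether the same ring-carbon inversion would matter as much in the longer chain of compound 2, or in the sulfur-containing ring of compound 1. They also leave open how a carboxylic acid or an amine in place of the fluorine on the shared core would change the gap between the two configurations.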